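From 4-methoxyphenyl to 3-bromophenyl on the shared core

The compounds below may be only part of what the source reports. "The series", "measured", "known", "first", "only" and "open" are said of these compounds alone.

Among the measured compounds shown here, in a functional assay on HT-1080 cells (Homo sapiens) for antiproliferative activity, read by MTT assay, with a stated time of 72 h (a lower number here means a stronger inhibitor, a higher number a weaker inhibitor), compound 3 `COc1ccc(-c2sccc2-c2cc(OC)c(OC)c(OC)c2)cc1` gives 4590 nM, the only true number so far. Compound 1 `CCOC(=O)c1cc(-c2cc(OC)c(OC)c(OC)c2)c(-c2cccc(Br)c2)s1` reads > 100000 nM, which is a limit of the assay and not a number. Compound 2 `COc1cc(-c2cc(C(=O)O)sc2-c2cccc(Br)c2)cc(OC)c1OC` reads > 100000 nM, again a limit. Compound 3 therefore stands clear of the limit of > 100000 nM in this assay, at which 2 of the 3 values shown sit.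

Compound 4 `COc1cc(-c2ccsc2-c2cccc(Br)c2)cc(OC)c1OC` keeps the core of compound 3 and changes one group: 3-bromophenyl in place of 4-methoxyphenyl on an aromatic carbon. The 3-bromophenyl replaces 4-methoxyphenyl on an aromatic carbon next to the ring sulfur.

For the measured compounds named here, the one measured step, a step that the two limits leave unreadable from compound 1 to compound 2, has no readable size and gives no measure for this change. Compound 1 and compound 2 share the 3-bromophenyl group with compound 4, but they also carry a carbonyl group that compound 4 lacks, so their readings do not isolate the group exchange. The expectation of weaker inhibition rests on compound 1, whose > 100000 nM is a limit. The expected step, a 2.6-fold higher number from compound 3 to compound 4 (0.42 log units; beyond the scatter), is towards weaker inhibition and of moderate size, with wide uncertainty. For compound 4 the estimated value in this assay is 12000 nM, with an expected range of 2500 nM to 60000 nM.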

Compound 4, half-maximal inhibitory concentration: > 100000 nM
Compound 4: a limit, no number; the forecaster's own chance of this, stated with the estimate: 25%; middle value at least 8.3-fold (0.92 log units) away from the limit.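

In this assay, among the compounds shown here, 3-bromophenyl in place of 4-methoxyphenyl on an aromatic carbon next to the ring sulfur gives an at least 21-fold higher number from compound 3 to compound 4 (1.33 log units; beyond the scatter), the first step with a readable size and the first measure of this exchange. The value of compound 4, > 100000 nM, is a limit of the assay and not a number. Compound 4 has neither the ethoxycarbonyl of compound 1 nor the carboxy of compound 2, yet it reads the same limit, so neither of those groups is needed for that reading, and 3-bromophenyl is the group that compound 1, compound 2 and compound 4 share, with compound 3, which lacks it, standing clear of: the limit of > 100000 nM in this assay, at which 3 of the 4 values shown sit.

Going by these compounds, the steps among compound 1, compound 2 and compound 4 cannot be read, so what ethoxycarbonyl or carboxy does on the shared core remains unknown while 3-bromophenyl is present. Also open, on these data alone, is whether chlorine or an amine in place of the bromine would bring the reading back to a true number.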